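The source may hold more compounds than are shown below. What is called first, only, known or untested is meant among the compounds shown, and "the series" means these compounds.

Compound 1 `Cc1nc(-c2cccc(C(=O)N3CCCC(C(=O)Nc4ccc(Cl)cc4)C3)c2)no1`: 0%
Compound 2 `O=C(Nc1ccc(Cl)cc1)C1CCCN(C(=O)c2cccc(-c3cnco3)c2)C1`: 0%
Compound 3 `Cc1nc(-c2cccc(C(=O)N3CCCC(C(=O)Nc4ccc(Cl)cc4)C3)c2)cs1`: 1%

In an ADME assay on PC-3 cells (Homo sapiens) for cytotoxicity, read by WST assay, tested at 100 uM (on this read-out lower numbers stand for less inhibition and higher numbers for more inhibition at the one concentration tested (going by the name of the read-out)), compound 3 holds the highest of these three numbers, but only by amounts within the scatter: a number 1 percentage points higher from compound 1 to compound 3 (within the scatter) and a number 1 percentage points higher from compound 2 to compound 3 (within the scatter). Compound 4 `O=C(Nc1ccc(Cl)cc1)C1CCCN(C(=O)c2cccc(-c3ccco3)c2)C1` has not been measured yet. It differs from compound 3 in one place: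

furan-2-yl in place of 2-methyl-1,3-thiazol-4-yl on an aromatic carbon

Going by the values given here, the steps that bear on this are the earlier exchanges of one five-membered aromatic ring for another on the same aromatic carbon, no change at the digits printed from compound 1 to compound 2 (within the scatter), a number 1 percentage points higher from compound 1 to compound 3 (within the scatter) and a number 1 percentage points higher from compound 2 to compound 3 (within the scatter), none of them beyond the scatter. The step from compound 3 to compound 4 in this assay is therefore expected to be no change at the digits printed from compound 3 to compound 4 (within the scatter). Compound 4 is expected to give 1% in this assay, with a range from 0% to 10%.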

Compound 4, a percentage reported as inhibition, at one concentration (the size of the read-out at that concentration, not a potency): 0%
Compound 4: the middle estimate sits 1 percentage points above what was measured; the measured number falls inside the stated range.
By their numbers in this assay, from the lowest: compounds 1, 2, 4 and 3 (each within the scatter of the next).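

In this assay the change to furan-2-yl gives a number 1 percentage points lower from compound 3 to compound 4 (within the scatter) and no change at the digits printed from compound 2 to compound 4 (within the scatter) and also no change at the digits printed from compound 1 to compound 4 (within the scatter) on this aromatic carbon. A five-membered aromatic ring with only 1 hetero atom therefore reads the same, within the scatter, as the three rings before it. Nothing at hand gives a reason for this sameness.

The compounds shown hold only five-membered aromatic rings at this place, so an amine, a carboxylic acid or a longer chain there remains open. Changes elsewhere on the shared core also remain open.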